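This account rests on a few compounds, and the source may have more. Where it says the series, first, only, none or still open, it means among the compounds named here.

Measured values in a functional assay on CHO cells with adenosine receptor A1 (Homo sapiens) as the target, read by cAMP accumulation and immunoassay, with a stated time of 6 min, tested at 10 uM; on this read-out lower numbers stand for a stronger effect and higher numbers for a weaker effect at the one concentration tested:

compound 1 `Nc1scc(CN2CCN(c3ccncc3)CC2)c1C(=O)c1ccc(Cl)cc1`: -15%
compound 2 `Nc1scc(CN2CCC(c3ccc(Cl)cc3)CC2)c1C(=O)c1ccc(Cl)cc1`: -61%
compound 3 `Nc1scc(CN2CCN(c3ccc(C(F)(F)F)cc3)CC2)c1C(=O)c1cccc(C(F)(F)F)c1`: -47%

Compound 1 gives the highest of the three numbers in this assay. Compound 3 is nearest, a number lower by an amount beyond the scatter; compound 2 is furthest, lower still and likewise beyond the scatter. Both compounds 2 and 3 carry a carbon-only aromatic ring where compound 1 carries pyridin-4-yl.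

Compound 4 `Nc1scc(CN2CCN(c3cc(Cl)ccc3Cl)CC2)c1C(=O)c1ccc(Cl)cc1` is the next compound in the series, not yet measured. It differs from compound 1 in one place: 2,5-dichlorophenyl in place of pyridin-4-yl on an amine nitrogen in a ring. Among the measured compounds shown here, no directly comparable step between measured compounds is available for this change, so the size of the step in this assay can only be judged from what compounds 2 and 3 show against compound 1. On that basis a step downward, beyond the scatter, is expected for compound 4, in the region of a number 30 percentage points lower from compound 1 to compound 4 (beyond the scatter). Compound 4 is accordingly estimated at -45%, with a range from -72% to -18%.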

Compound 4, a percentage reported as activity, at one concentration (the size of the read-out at that concentration, not a potency): -62%
Compound 4: middle estimate off by 17 percentage points, on the high side; the range from low to high includes it.
By their numbers in this assay, from the lowest: compounds 4 and 2 (each within the scatter of the next); then compound 3; then compound 1.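

In this assay, 2,5-dichlorophenyl in place of pyridin-4-yl on an amine nitrogen in a ring gives a number 47 percentage points lower from compound 1 to compound 4 (beyond the scatter), the only step shown in which this group changes and the rest of the compound stays the same. The size of this step shows that the read-out at this position depends strongly on the group carried there, a point that compounds 2 and 3 could not settle, as each differs from compound 1 in more than one place. No measurement at hand accounts for the step.

The change removes the ring nitrogen and adds two chlorine atoms at once, so an unsubstituted phenyl and a monochlorophenyl are needed to separate the two. Also open, on these data alone, is how a methoxy group or an amine on this phenyl ring would read in this assay.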